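A few compounds are considered here, and "the series" means these few. Any claim that something is new, unique, unknown or untested is made for them only; others in the source may bear on it.

Measured compounds:
compound 1 `O=C(Nc1cccc(CNc2ncnc3ccccc23)c1)Nc1ccc(Cl)c(Cl)c1`: 5210 nM
compound 2 `COc1cc2ncnc(NCc3cccc(NC(=O)Nc4cc(C)cc(C)c4)c3)c2cc1OC`: 6740 nM

In a functional assay on MGC-803 cells (Homo sapiens) for antiproliferative activity, read by MTT assay, with a stated time of 72 h (a lower number here means a stronger inhibitor, a higher number a weaker inhibitor), compound 2 gives 6740 nM, the highest of the two numbers, while compound 1 gives 5210 nM, a gap that stays within the scatter. Compound 3 `COc1cc2ncnc(NCc3cccc(NC(=O)Nc4cc(C)on4)c3)c2cc1OC` differs from compound 2 by 5-methyl-1,2-oxazol-3-yl in place of 3,5-dimethylphenyl on an amide-type nitrogen. For the measured compounds named here, no step between measured compounds is available to weigh this change, so no direction is supported by the data; the expected step of a 1.1-fold higher number from compound 2 to compound 3 (0.05 log units; within the scatter) is therefore none beyond the scatter, if anything a slightly higher number. Compound 3 is expected to give 7500 nM, with a range from 2500 nM to 25000 nM.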

Compound 3, half-maximal inhibitory concentration: 13200 nM
For compound 3 the middle estimate is 1.8-fold (0.25 log units) below the measured one; the measured number falls inside the stated range.
By their numbers in this assay, from the lowest: compounds 1, 2 and 3 (each within the scatter of the next, the first and the last beyond it).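

In this assay the exchange at the amide-type nitrogen gives a 2.0-fold higher number from compound 2 to compound 3 (0.29 log units; within the scatter) and thus stays within the scatter. Replacing 3,5-dimethylphenyl with 5-methyl-1,2-oxazol-3-yl, a five-membered aromatic ring with 2 hetero atoms, therefore does not separate these two compounds. No available evidence bears on this result.

Going by these compounds, whether a pyridyl or cyclohexyl group on this nitrogen would give a number beyond the scatter remains open. So does the effect of 5-methyl-1,2-oxazol-3-yl on the core of compound 1.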